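Terminal alkyne in place of phenylethynyl on the shared core

The compounds below may be only part of what the source reports. "The series", "measured", "known", "first", "only" and "open" are said of these compounds alone.

The series is followed in a functional assay on NCI-H522 cells (Homo sapiens) for cytotoxicity, with a stated time of 3 days; a higher number here means a weaker inhibitor, a lower number a stronger inhibitor. Compound 1 `C#CCNC(=O)c1csc(C#Cc2ccccc2)n1` gives only a limit there: in this assay compound 1 gives > 40000 nM, which is a limit of the assay and not a number. Compound 2 `C=Cc1nc(C(=O)OCC)cs1` also gives only a limit: in this assay compound 2 gives > 40000 nM. Where compound 1 stands is therefore set by the limit of > 40000 nM in this assay, at which 2 of the 2 values shown sit; no measured value in the series falls inside the reported range.

Compound 3 `C#CCNC(=O)c1csc(C#C)n1` is the unmeasured partner of compound 1. The change is hydrogen in place of phenyl on a triple-bonded carbon on the core of compound 1. For the measured compounds named here, no measured step between two compounds is available to scale this change.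

With both shown values sitting at the limit, no step beyond the scatter is expected; compound 3 is expected to return a limit as well, the step that the limit leaves unreadable from compound 1 to compound 3 being an estimate. The estimate for compound 3 is 50000 nM with a range from 20000 nM to 200000 nM.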

Compound 3, half-maximal inhibitory concentration: 2100 nM
Compound 3: the middle estimate sits 24-fold (1.38 log units) above what was measured; measured number below the stated range.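

In this assay, for the compounds shown here, the triple-bonded carbon on the core proves to be a place that responds to change: hydrogen in place of phenyl there gives an at least 19-fold lower number from compound 1 to compound 3 (1.27 log units; beyond the scatter), and the series now holds a measured number where the earlier compounds gave only limits. As far as these compounds go, the true size of this step stays unknown, since its starting end is a limit of the assay and not a number: the limit of > 40000 nM in this assay, at which 2 of the 3 values shown sit. Within this one pair, phenyl on that carbon goes with the limit and hydrogen with a measurable cytotoxic effect, though a single pair gives no cause for the difference.

Still open, from the compounds shown here alone, is whether a small group on that carbon, such as methyl or a short alkyl chain, keeps the number of compound 3. Also open, going by these compounds, is how an amine or a hydroxymethyl group there would read in this assay.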